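Methoxy in place of methyl: outlook for compound 4

This account rests on a few compounds, and the source may have more. Where it says the series, first, only, none or still open, it means among the compounds named here.

Compound 2 `Cc1ccccc1Nc1nc(SCc2ccc(C(F)(F)F)cc2)nc2ccccc12` and compound 3 `Cc1ccc(Nc2nc(SCc3ccc(C(F)(F)F)cc3)nc3ccccc23)cc1` share one core and differ only in the aryl group on the ring nitrogen, (4-methylphenyl in place of 2-methylphenyl on a nitrogen on an aromatic ring). In a functional assay on MGC-803 cells (Homo sapiens) for cytotoxicity, read by MTT assay, with a stated time of 72 h (a higher number here means a weaker inhibitor, a lower number a stronger inhibitor), compound 2 gives 24400 nM and compound 3 gives 36100 nM; the step of a 1.5-fold higher number from compound 2 to compound 3 (0.17 log units; within the scatter) lies within the scatter, so the two are not told apart. Compound 1 `COc1ccccc1Nc1nc(SCc2ccc(C(F)(F)F)cc2)nc2ccccc12` carries the change (methoxy in place of methyl on an aromatic carbon). In this assay compound 1 reaches only a limit, > 50000 nM, as recorded in the limit of > 50000 nM in this assay, at which 1 of the 3 values shown sits. The step of an at least 2.0-fold higher number from compound 2 to compound 1 (0.31 log units; beyond the scatter) is thus a floor rather than a finished number.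

Compound 4 `COc1ccc(Nc2nc(SCc3ccc(C(F)(F)F)cc3)nc3ccccc23)cc1` is not yet measured; it applies to compound 3 the change (methoxy in place of methyl on an aromatic carbon). For the measured compounds named here, this is the same kind of change as the one made from compound 2 to compound 1, but the place differs: there the entering group sits ortho to a large group, here para to a large group. Starting from compound 3 at 36100 nM, a step of the size seen in an at least 2.0-fold higher number from compound 2 to compound 1 (0.31 log units; beyond the scatter) is expected to carry compound 4 past the ceiling of this assay. The expected step is a 1.9-fold higher number from compound 3 to compound 4 (0.29 log units; within the scatter). Compound 4 is therefore estimated at 70000 nM, between 25000 nM and 200000 nM, with a real chance that only a limit is reported.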

Compound 4, half-maximal inhibitory concentration: 13800 nM
Estimate against measurement, compound 4: 5.1-fold (0.71 log units) above, and the stated range ends above it.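

In this assay, methoxy in place of methyl does not carry over from one core to the other with a single size or direction, as a 2.6-fold lower number from compound 3 to compound 4 (0.42 log units; beyond the scatter) runs the opposite way to the earlier step: the same change on two cores in this assay, an at least 2.0-fold higher number (0.31 log units; beyond the scatter) from compound 2 to compound 1 and a 2.6-fold lower number (0.42 log units; beyond the scatter) from compound 3 to compound 4, at least 5.3-fold (0.72 log units) apart, beyond the scatter of two such steps

The step of a 1.8-fold lower number from compound 2 to compound 4 (0.25 log units; within the scatter) tells nothing apart, and an at least 3.6-fold lower number from compound 1 to compound 4 (0.55 log units; beyond the scatter) is only a floor, so neither gives a finished ranking among these aryl groups. With just two matched pairs, the result shows that this change depends on its place in this series, but it gives no general rule and no exact size for the gap between the two steps, which rests on a limit: the limit of > 50000 nM in this assay, at which 1 of the 4 values shown sits.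

On these data alone, what stays open is whether the lower number of compound 4 belongs to methoxy itself or would also appear with an ethoxy group, a hydroxyl group or an amine in the same place. Also open, as far as these compounds go, is whether the same step holds when the trifluoromethyl group of the shared core is replaced by a nitrile.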